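Cytotoxicity working notes on compounds 1 to 4

A few compounds are considered here, and "the series" means these few. Any claim that something is new, unique, unknown or untested is made for them only; others in the source may bear on it.

Measured so far:
Compound 1 `O=c1n(Cc2nc3cc(F)ccn3c2CCCCO)c2cnccc2n1C1CC1` in an ADME assay on HEp-2 cells (Homo sapiens) for cytotoxicity, read by CCK-8 assay, with a stated time of 6 days (a higher number here means that more compound is tolerated, a lower number that less compound is tolerated), gives > 100000 nM, a limit of the assay and not a number.
Compound 2 `O=c1n(Cc2nc3ccccn3c2CCCCO)c2cnccc2n1C1CC1` in this assay gives > 100000 nM, also a limit.
Compound 3 `O=c1n(Cc2nc3cc(Cl)ccn3c2CO)c2cnccc2n1C1CC1` in this assay gives > 100000 nM, again a limit.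

Compound 3 therefore stands only at a limit, as do both other measured values, all three sitting at the limit of > 100000 nM in this assay, at which 3 of the 3 values shown sit. Going by the values given here, the one measured step, a step that the two limits leave unreadable from compound 1 to compound 2, lies between two limits and is unreadable. The change to compound 4 `CCCCNc1c(Cn2c(=O)n(C3CC3)c3ccncc32)nc2cc(Cl)ccn12` is butylamino in place of hydroxymethyl on an aromatic carbon. Among the compounds with values here, no measured step bears readably on this change, so for compound 4 another limit or a value near it is expected. The step of an at least 1.2-fold lower number from compound 3 to compound 4 (0.09 log units; that floor lies within the scatter) is expected to be none beyond the scatter. Compound 4 is estimated at 80000 nM, within 25000 nM to 250000 nM.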

Compound 4, half-maximal cytotoxic concentration: > 100000 nM
Compound 4: only a limit was reported (the forecaster's own chance of this, stated with the estimate: 65%); at least 1.2-fold (0.09 log units) between middle value and limit.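

No step can be read from compound 3 to compound 4, since both values are limits and not numbers: the limit of > 100000 nM in this assay, at which 4 of the 4 values shown sit.

The compounds shown leave open whether butylamino in place of hydroxymethyl changes anything in this assay, where none of them yet gives a number.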